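The source may report more compounds than this note shows. Statements on the series, on what has been measured and on what is new or still open speak of the compounds shown alone.

In a functional assay on HeLa cells (Homo sapiens) for inhibition, with a stated time of 72 h (on this read-out lower numbers stand for stronger inhibition and higher numbers for weaker inhibition), compound 1 `NC1CCC(Nc2nc(NCc3ccc(-c4ccco4)nc3)c3ncn(C4CCCC4)c3n2)CC1` gives 30 nM as its result. Two close relatives differ from it only in the furan-2-yl group: compound 2 `NC1CCC(Nc2nc(NCc3ccc(-c4cccs4)nc3)c3ncn(C4CCCC4)c3n2)CC1` reads 40 nM and compound 3 `NC1CCC(Nc2nc(NCc3ccc(-c4ccsc4)nc3)c3ncn(C4CCCC4)c3n2)CC1` reads 75 nM on the same scale. Compound 1 therefore sits level with one relative, with a 1.3-fold higher number from compound 1 to compound 2 (0.12 log units; within the scatter) inside the scatter, and apart from the other, with a 2.5-fold higher number from compound 1 to compound 3 (0.40 log units; beyond the scatter) as a modest step.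

Compound 4 `CC(C)(O)CNc1nc(NCc2ccc(-c3ccco3)nc2)c2ncn(C3CCCC3)c2n1` changes a different part of the molecule, 2-hydroxy-2-methylpropyl in place of 4-aminocyclohexyl on a nitrogen on an aromatic ring in all: 2-hydroxy-2-methylpropyl in place of 4-aminocyclohexyl on a nitrogen on an aromatic ring. Going by the values given here, none of the measured steps touches this group, so they offer only a sense of scale, the widest being a 2.5-fold higher number from compound 1 to compound 3 (0.40 log units; beyond the scatter) for a swap elsewhere. This change removes a whole ring-bearing group, so a larger step toward weaker inhibition is expected in this assay, though with wide uncertainty. The expected step is an 8.3-fold higher number from compound 1 to compound 4 (0.92 log units; beyond the scatter) by this estimate. For compound 4 the estimated value is 250 nM with an expected range from 60 nM to 1000 nM at this stage.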

Compound 4, half-maximal inhibitory concentration: 667 nM
Estimate against measurement, compound 4: 2.7-fold (0.43 log units) below; the range from low to high includes it.
By their numbers in this assay, from the lowest: compounds 1, 2 and 3 (each within the scatter of the next, the first and the last beyond it); then compound 4.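

Replacing 4-aminocyclohexyl with 2-hydroxy-2-methylpropyl on this nitrogen gives a 22-fold higher number from compound 1 to compound 4 (1.35 log units; beyond the scatter) in this assay, a large move toward weaker inhibition and much wider than the widest step among the furan and thiophene swaps, a 2.5-fold higher number from compound 1 to compound 3 (0.40 log units; beyond the scatter). So this position responds far more strongly to change than the earlier compounds could show, and this open chain does not stand in for the 4-aminocyclohexyl group. The two groups count the same hydrogen-bond donors and acceptors, yet the swap removes a ring and exchanges nitrogen for oxygen at once, and nothing measured here explains the loss.

The ring and the amine therefore cannot be told apart as the source of the step. A 4-hydroxycyclohexyl group, which keeps the ring, or an open chain ending in an amine would help to separate the two.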